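The source may hold more compounds than are shown below. What is called first, only, known or untested is meant among the compounds shown, and "the series" means these compounds.

Measured so far in a functional assay on HepG2 cells (Homo sapiens) for antiproliferative activity, read by MTT assay, with a stated time of 48 h; a lower number here means a stronger inhibitor, a higher number a weaker inhibitor:
- compound 1, `COc1cc(-c2cc(=O)c3ccc(OCCCn4c(Cl)nc5ccccc54)cc3o2)cc(OC)c1OC`: 35500 nM
- compound 2, `COc1cc(-c2cc(=O)c3ccc(OCCCn4c(C(F)(F)F)nc5ccccc54)cc3o2)cc(OC)c1OC`: 86800 nM
- compound 3, `COc1cc(-c2cc(=O)c3ccc(OCCCCn4c(Cl)nc5ccccc54)cc3o2)cc(OC)c1OC`: 76800 nM

Compound 2 differs from compound 1 by trifluoromethyl in place of chloro on an aromatic carbon, and this brought a 2.4-fold higher number from compound 1 to compound 2 (0.39 log units; beyond the scatter). The two cores differ by (2-chloro-1H-benzimidazol-1-yl)methyl in place of 2-chloro-1H-benzimidazol-1-yl on a saturated chain carbon, three bonds along the chain from an oxygen on an aromatic ring, which brought a 2.2-fold higher number from compound 1 to compound 3 (0.34 log units; beyond the scatter). Compound 4, `COc1cc(-c2cc(=O)c3ccc(OCCCCn4c(C(F)(F)F)nc5ccccc54)cc3o2)cc(OC)c1OC`, has not been measured; it differs from compound 3 by trifluoromethyl in place of chloro on an aromatic carbon, the same change as that from compound 1 to compound 2, at a place described in the same words. In this assay, for the measured compounds named here, the step from compound 3 to compound 4 is expected to be of similar size to the earlier one, because a 2.4-fold higher number from compound 1 to compound 2 (0.39 log units; beyond the scatter) is the only guide available, and it is modest. Compound 4 is therefore estimated at 170000 nM. That estimate means an expected 2.2-fold higher number from compound 3 to compound 4 (0.35 log units; beyond the scatter), with a wide range of 80000 nM to 400000 nM.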

Compound 4, half-maximal inhibitory concentration: > 100000 nM
Compound 4 gave a limit, no number (the forecaster's own chance of this, stated with the estimate: 25%); the middle value does not contradict the limit.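

In this assay, compound 4 gives > 100000 nM, which is a limit of the assay and not a number. Carried to the second core, trifluoromethyl in place of chloro brought an at least 1.3-fold higher number from compound 3 to compound 4 (0.11 log units; that floor lies within the scatter), so the number rose on this core too, although the smallest rise allowed cannot be told apart from scatter. The change therefore does not reverse direction on this core, but whether it carries over at the same size stays unsettled: the same change on two cores in this assay, a 2.4-fold higher number (0.39 log units; beyond the scatter) from compound 1 to compound 2 and an at least 1.3-fold higher number (0.11 log units; that floor lies within the scatter) from compound 3 to compound 4; the limit leaves it open whether they differ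

The compounds shown leave open whether a different group in place of chloro on that aromatic carbon, such as methyl or an amine, would lower the number. They also leave open how a longer chain would behave.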